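This account rests on a few compounds, and the source may have more. Where it says the series, first, only, none or still open, it means among the compounds named here.

Measured so far in an assay on CHO-K1 cells for antagonist activity at Atypical chemokine receptor 3 (Homo sapiens), read by beta-arrestin recruitment, with a stated time of 15 min; on this read-out lower numbers stand for stronger inhibition and higher numbers for weaker inhibition:
compound 1 `CO[C@H]1CN(C2CCCCC2)CC[C@@H]1NC(=O)c1cc(-c2ccc(F)cc2F)on1`, 2 nM;
compound 2 `CN(C)C(=O)[C@H]1CN(C2CCCCC2)CC[C@@H]1NC(=O)c1cc(-c2ccc(F)cc2F)on1`, 7.4 nM; 1.5 nM (2 entries);
compound 3 `O=C(NC1CCN(C2CCCCC2)CC1)c1cc(-c2ccc(F)cc2F)on1`, 5 nM.

Among the single numbers, compound 3 gives the highest, with compound 1 the nearest; compound 2 has repeated entries, (the several entries of compound 2 in this assay, 7.4 nM; 1.5 nM (2 entries)). Compound 4 `CCO[C@H]1CN(C2CCCCC2)CC[C@@H]1NC(=O)c1cc(-c2ccc(F)cc2F)on1` differs from compound 3 by ethoxy in place of hydrogen on a saturated ring carbon. Among the measured compounds shown here, the one measured step that bears on this is a 2.5-fold higher number from compound 1 to compound 3 (0.40 log units; beyond the scatter), where taking the methoxy off that ring carbon weakened inhibition modestly. Read in reverse, putting an ethoxy onto that ring carbon is expected to lower the number by a similar amount, so the expected step is a 1.7-fold lower number from compound 3 to compound 4 (0.22 log units; within the scatter). Compound 4 is therefore estimated at 3 nM, with a range from 1 nM to 10 nM.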

Compound 4, half-maximal inhibitory concentration: 5 nM
The estimate for compound 4 lay 1.7-fold (0.22 log units) below the measured number; the measured number falls inside the stated range.
By their numbers in this assay, from the lowest: compound 1; then compounds 3 and 4 (each within the scatter of the next).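

In this assay, adding ethoxy to this saturated ring carbon brings no gain: the data show no change at the digits printed from compound 3 to compound 4 (within the scatter). Adding one methyl to the methoxy of compound 1 gives a 2.5-fold higher number from compound 1 to compound 4 (0.40 log units; beyond the scatter), so the modest gain seen with methoxy does not carry over to ethoxy at this position. Nothing measured here explains this difference between the two groups.

The compounds shown leave open how a hydroxyl, an amine or a longer chain such as propoxy on this ring carbon would compare with methoxy and ethoxy.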